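The source may report more compounds than this note shows. Statements on the series, on what has been measured and on what is new or still open speak of the compounds shown alone.

Compounds measured in an assay on microsomes for inhibition of Amine oxidase [flavin-containing] B (Homo sapiens), read by fluorescence and spectrophotometry, with a stated time of 20 min; a lower number here means a stronger inhibitor, a higher number a weaker inhibitor:
compound 1, `O=c1ccoc2ccc(OCc3cccc(Cl)c3)cc12`, 3.6 nM
compound 2, `O=c1ccoc2ccc(OCc3cccc(F)c3)cc12`, 13 nM

Compound 2 stands at the highest of the two numbers shown; its nearest neighbour is compound 1, and the step of a 3.6-fold higher number from compound 1 to compound 2 (0.56 log units; beyond the scatter) lies beyond the scatter. Compound 3, `Cc1cccc(COc2ccc3occc(=O)c3c2)c1`, differs from compound 2 by methyl in place of fluoro on an aromatic carbon. Within the data shown here, the only measured step that bears on this change is a 3.6-fold higher number from compound 1 to compound 2 (0.56 log units; beyond the scatter), which shows that exchanging one substituent for another at this carbon can move the number by a modest amount. The present change is not a halogen swap, so that step is only an indirect guide. Compound 3 is therefore expected to come in somewhat lower than compound 2, with the step of a 2.6-fold lower number from compound 2 to compound 3 (0.41 log units; beyond the scatter) estimated to be modest and towards a stronger inhibitor. The estimate for compound 3 in this assay is 5 nM, with a range from 2 nM to 15 nM.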

Compound 3, half-maximal inhibitory concentration: 19 nM
Beside the measured number, compound 3's estimate is 3.8-fold (0.58 log units) below it; measured number outside the range, above it.
By their numbers in this assay, from the lowest: compound 1; then compounds 2 and 3 (each within the scatter of the next).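

In this assay methyl and fluoro on this aromatic carbon cannot be told apart, as the step between them lies within the scatter (a 1.5-fold higher number from compound 2 to compound 3 (0.16 log units; within the scatter)). Chloro alone stands apart among the three substituents, since methyl in its place gives a step beyond the scatter (a 5.3-fold higher number from compound 1 to compound 3 (0.72 log units; beyond the scatter)), so compound 1 remains the strongest inhibitor of the three and neither replacement of its chloro matches it. Nothing available explains why chloro differs from the other two groups. The compounds shown leave open whether another group at this carbon, such as bromo, methoxy, an amine or a carboxylic acid, would match chloro or fall with fluoro and methyl. They also leave open whether the advantage of chloro would hold at another carbon of the same ring.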